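This account rests on a few compounds, and the source may have more. Where it says the series, first, only, none or still open, it means among the compounds named here.

Within the data shown here, in a functional assay on MCF7 cells (Homo sapiens) for cytotoxicity, read by MTT assay, with a stated time of 68 h (a lower number here means a stronger inhibitor, a higher number a weaker inhibitor), three compounds have numbers so far. Compound 1 (`O=C(/C=C/c1cccc(OCc2ccccc2)c1)c1ccc(Cl)cc1Cl`) gives 9400 nM, and compound 3 (`COc1cc(C2Oc3cc(/C=C/C(=O)c4ccccc4O)ccc3OC2CO)ccc1O`) gives 12100 nM. Compound 2 (`O=C(/C=C/c1cccc(OCc2ccccc2)c1)c1ccc(Cl)cc1`) gives 24800 nM, the highest number of the three, which makes it the weakest inhibitor among them. Among the measured compounds shown here, compound 3 is joined to the others by no single-place step, so it offers no direct guide here.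

Compound 4 (`O=C(/C=C/c1cccc(OCc2ccccc2)c1)c1ccccc1`) follows from compound 2 by one change: hydrogen in place of chloro on an aromatic carbon. This is hydrogen in place of chloro on an aromatic carbon, para to a large group, so that 4-chlorophenyl becomes phenyl, and compound 4 carries no chloro at all.

For the measured compounds named here, one measured step bears on this change, the same kind of exchange made at the other chloro: a 2.6-fold higher number from compound 1 to compound 2 (0.42 log units; beyond the scatter). That single modest step is thin evidence, since the chloro that leaves here is a different one, but it points towards a further rise of similar size. The expected change is a 1.7-fold higher number from compound 2 to compound 4 (0.23 log units; within the scatter), in the direction of weaker inhibition. For compound 4 the estimated value in this assay is 42000 nM, with an expected range from 20000 nM to 85000 nM.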

Compound 4, half-maximal inhibitory concentration: 9800 nM
Compound 4: the middle estimate sits 4.3-fold (0.63 log units) above what was measured, outside the stated range (below it).
By their numbers in this assay, from the lowest: compounds 1, 4 and 3 (each within the scatter of the next); then compound 2.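

In this assay, the same exchange of chloro for hydrogen now runs the other way: a 2.5-fold lower number from compound 2 to compound 4 (0.40 log units; beyond the scatter) stands against the earlier 2.6-fold higher number from compound 1 to compound 2 (0.42 log units; beyond the scatter) as the opposite direction, so the change has no single effect across this series, and its outcome differs with which chloro leaves and what else remains on the ring. Among these compounds, removing both chloro groups gives a 1.0-fold higher number from compound 1 to compound 4 (0.02 log units; within the scatter) and so leaves phenyl and 2,4-dichlorophenyl indistinguishable in this assay, while compound 2, with its 4-chlorophenyl group, stands apart from both as the one with the higher number. Nothing available here accounts for this reversal.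

The compounds shown leave open how a ring carrying only the other chloro would fit among these three, which would show whether the two chloro groups truly depend on each other. They also leave open whether this behaviour belongs to chloro alone or would recur with a bromo, a methyl or a methoxy group on the same aromatic carbon, para to a large group.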